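A Chloro Group in Place of Hydrogen on Compound 1

The compounds below may be only part of what the source reports. "The series", "measured", "known", "first", "only" and "open" are said of these compounds alone.

Compound 1 `CC1CC(=O)N(CC(=O)N2CCN(c3ccccc3)CC2)C1=O` was tested in a functional assay on the whole organism (strain CD1) with Mus musculus as the target, in the maximal electroshock model, with a stated time of 0.5 h (on this read-out lower numbers stand for an effect already at smaller amounts and higher numbers for an effect only at larger amounts of compound), where compound 1 gives 300 mg/kg, the higher of the two numbers recorded. Within the data shown here, compound 2 `CC1CC(=O)N(CC(=O)N2CCN(c3cccc(C(F)(F)F)c3)CC2)C1=O` gives 100 mg/kg in this assay, and the only step seen so far is a 3.0-fold lower number from compound 1 to compound 2 (0.48 log units; beyond the scatter). Compound 3 `CC1CC(=O)N(CC(=O)N2CCN(c3ccccc3Cl)CC2)C1=O` differs from compound 1 by chloro in place of hydrogen on an aromatic carbon. That one measured step concerns a different group at another place, so only a modest step in the same direction, or none beyond the scatter, is expected here. Compound 3 is therefore estimated at 200 mg/kg, within 100 mg/kg to 400 mg/kg. This expectation corresponds to a 1.5-fold lower number from compound 1 to compound 3 (0.18 log units; within the scatter).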

Compound 3, minimum effective dose: 300 mg/kg
Compound 3: the middle estimate sits 1.5-fold (0.18 log units) below what was measured, within the range that was stated.
By their numbers in this assay, from the lowest: compound 2; then compounds 1 and 3 (each within the scatter of the next).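

Going from phenyl to 2-chlorophenyl gives no change at the digits printed from compound 1 to compound 3 (within the scatter) in this assay. At this aromatic carbon, ortho to a large group, a single chloro therefore leaves the number unchanged within the scatter, unlike the trifluoromethyl change at another place, which gave a 3.0-fold lower number from compound 1 to compound 2 (0.48 log units; beyond the scatter). Nothing available explains this absence of a step.

The compounds shown leave open whether a methoxy group or an amine on this same aromatic carbon would shift the number. They also leave open whether chloro on another carbon of the ring would do so.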